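Swapping the tetrazole for an isothiazole on the shared core

This account rests on a few compounds, and the source may have more. Where it says the series, first, only, none or still open, it means among the compounds named here.

Three compounds share one core and differ only in the small ring attached to the benzene. Compound 1 `CCC(C)(C)Cc1c[nH]c(CCc2ccc(-n3ncnn3)cc2)n1` carries a tetrazole there, compound 2 `CCC(C)(C)Cc1c[nH]c(CCc2ccc(-c3cnccn3)cc2)n1` a pyrazine, and compound 3 `CCC(C)(C)Cc1c[nH]c(CCc2ccc(-c3cccnc3)cc2)n1` a pyridine. In a functional assay on HEK293 cells for agonist activity at Bombesin receptor subtype-3 (Mus musculus), read by luminescence and calcium flux, with a stated time of 10 min (a lower number here means that less compound is needed, a higher number that more compound is needed for the effect), compound 1 gives 25 nM, the highest number of the three; compound 2 gives 11 nM and compound 3 gives 4.3 nM. The changes seen so far were a 2.3-fold lower number from compound 1 to compound 2 (0.36 log units; beyond the scatter) and a 5.8-fold lower number from compound 1 to compound 3 (0.76 log units; beyond the scatter), with a 2.6-fold lower number from compound 2 to compound 3 (0.41 log units; beyond the scatter) between the two replacements.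

Compound 4 `CCC(C)(C)Cc1c[nH]c(CCc2ccc(-c3ccns3)cc2)n1` differs from compound 1 by 1,2-thiazol-5-yl in place of 2H-tetrazol-2-yl on an aromatic carbon. Both earlier swaps of the tetrazole for another aromatic ring lowered the number in this assay, so a similar move, a 2.8-fold lower number from compound 1 to compound 4 (0.44 log units; beyond the scatter), is expected here. The incoming ring is five-membered like the one it replaces, so the expected step is kept close to the smaller of the two observed ones. Compound 4 is therefore estimated to give 9 nM, with a likely range from 3 nM to 27 nM.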

Compound 4, half-maximal effective concentration: 3.1 nM
Estimate against measurement, compound 4: 2.9-fold (0.46 log units) above; low and high end bracket the measured number.
By their numbers in this assay, from the lowest: compounds 4 and 3 (each within the scatter of the next); then compound 2; then compound 1.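

In this assay, a five-membered aromatic ring at this position can give a number as low as the six-membered rings do: the step is an 8.1-fold lower number from compound 1 to compound 4 (0.91 log units; beyond the scatter), although the entering and leaving groups have the same ring size and the same count of heavy atoms, so these two features do not separate them. The same replacement gives a 3.5-fold lower number from compound 2 to compound 4 (0.55 log units; beyond the scatter), while a 1.4-fold lower number from compound 3 to compound 4 (0.14 log units; within the scatter) leaves compound 3 and compound 4 indistinguishable here. No measured evidence explains why the 1,2-thiazol-5-yl group differs from the tetrazole.

The compounds shown leave open whether the ring sulfur or the ring nitrogen matters more, as a thiophene or a plain phenyl ring would test. On these data alone, how an amide or an amine would fare in this place also remains open.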